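Alkyl isomers on the amide nitrogen of a TRPM8 agonist series

The source may hold more compounds than are shown below. What is called first, only, known or untested is meant among the compounds shown, and "the series" means these compounds.

The measured compounds:
compound 1, `Cc1ccc(OCC(=O)N(Cc2cccs2)c2ccn(C)n2)cc1`, 855 nM
compound 2, `CON(Cc1cccs1)C(=O)COc1ccc(C)cc1`, 10 nM
compound 3, `CCC(C)N(Cc1cccs1)C(=O)COc1ccc(C)cc1`, 2000 nM

All three share the same core and differ only in the group carried on the amide-type nitrogen. In an assay on HEK293 cells for agonist activity at transient receptor potential cation channel subfamily M member 8 (Homo sapiens), read by fluorescence and calcium flux, with a stated time of 15 min (a lower number here means that less compound is needed, a higher number that more compound is needed for the effect), compound 3 carries the highest number of the three. Its nearest neighbour is compound 1, at a 2.3-fold higher number from compound 1 to compound 3 (0.37 log units; beyond the scatter), while compound 2 lies furthest away, at a 200-fold higher number from compound 2 to compound 3 (2.30 log units; beyond the scatter). The remaining pair, compound 1 and compound 2, shows an 86-fold lower number from compound 1 to compound 2 (1.93 log units; beyond the scatter).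

Compound 4, `Cc1ccc(OCC(=O)N(Cc2cccs2)C(C)(C)C)cc1`, is not yet measured. It differs from compound 3 by tert-butyl in place of sec-butyl on an amide-type nitrogen. Among the measured compounds shown here, no measured step compares two alkyl groups at this nitrogen; the steps that bear on the place are those that exchange the pyrazolyl, methoxy and sec-butyl groups there, and they range from modest to large. For an exchange of one four-carbon group for another of the same composition, the expectation in this assay is a step no larger than the scatter, or at most a modest one in either direction, with the measured large steps arising from changes of a different kind. The expected step is a 1.3-fold higher number from compound 3 to compound 4 (0.10 log units; within the scatter), so compound 4 is estimated at 2500 nM, with a range from 800 nM to 8000 nM.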

Compound 4, half-maximal effective concentration: 11000 nM
Compound 4: the middle estimate sits 4.4-fold (0.64 log units) below what was measured; the whole stated range lies below it.
By their numbers in this assay, from the lowest: compound 2; then compound 1; then compound 3; then compound 4.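

In this assay, the exchange of one four-carbon group for another at the amide-type nitrogen proves not to be neutral: a 5.5-fold higher number from compound 3 to compound 4 (0.74 log units; beyond the scatter) even though the same atoms are only joined differently, and the counted features of the leaving and entering groups are the same. The earlier compounds shown here showed large steps only between groups of different composition, whereas this pair shows that the arrangement of the carbons in the group at this place also moves the number beyond the scatter, and tert-butyl widens the span of the series further, with a 13-fold higher number from compound 1 to compound 4 (1.11 log units; beyond the scatter) and a 1100-fold higher number from compound 2 to compound 4 (3.04 log units; beyond the scatter) as the largest step among the four compounds. Nothing available here bears on why the two isomers differ, so the result gives the size of the step but not its origin.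

The compounds shown leave open where a straight butyl chain, a smaller ethyl group or a cyclopropyl ring at this nitrogen would fall relative to sec-butyl and tert-butyl. They also leave open whether an ethoxy group would stay close to methoxy, which in compound 2 gives 10 nM in this assay.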